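Swapping the aryl group on a weak growth inhibitor

The compounds below may be only part of what the source reports. "The series", "measured", "known", "first", "only" and "open" are said of these compounds alone.

Measured so far in a functional assay on DU-145 cells (Homo sapiens) for inhibition, read by trypan blue exclusion, with a stated time of 96 h (on this read-out lower numbers stand for stronger inhibition of growth and higher numbers for weaker inhibition of growth), are two compounds:
Compound 1 `Cc1ccc(CS/C(=C/c2c(O)cc(O)cc2O)C(=O)c2ccc(Cl)cc2)cc1` gives 50000 nM
Compound 2 `Cc1ccc(CS/C(=C/c2ccc(N(C)C)cc2)C(=O)c2ccc(Cl)cc2)cc1` gives > 100000 nM as a limit

Compound 2 stands at the limit of > 100000 nM in this assay, at which 1 of the 2 values shown sits, and so has no exact number. Among the measured compounds shown here, the one measured step is an at least 2.0-fold higher number from compound 1 to compound 2 (0.30 log units; that floor lies within the scatter) with 4-(dimethylamino)phenyl in place of 2,4,6-trihydroxyphenyl. This single step gives only a floor, so it offers little guidance on size.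

Compound 3 `Cc1ccc(CS/C(=C/c2ccccc2Br)C(=O)c2ccc(Cl)cc2)cc1` has not yet been measured. It carries 2-bromophenyl in place of 4-(dimethylamino)phenyl on a double-bonded chain carbon bound to a double-bonded chain carbon, and the counted difference is 2-bromophenyl in place of 4-(dimethylamino)phenyl on a double-bonded chain carbon bound to a double-bonded chain carbon in full.

The starting point is a limit, so the size of the new step cannot be fixed closely. For the measured compounds named here, compound 1 at 50000 nM is the only true number available, and the expectation leans on that value. A modest move towards a lower number is expected, which gives an estimated at least 2.5-fold lower number from compound 2 to compound 3 (0.39 log units; beyond the scatter) with wide uncertainty. For compound 3 the estimated value is 40000 nM with 8000 nM to 100000 nM as its expected range.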

Compound 3, concentration for 50% growth inhibition: 10000 nM
Compound 3: the middle estimate sits 4.0-fold (0.60 log units) above what was measured, and the stated range covers the measured number.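

In this assay, this double-bonded chain carbon now shows a change in the aryl group that clearly exceeds the scatter: 2-bromophenyl in place of 2,4,6-trihydroxyphenyl gives a 5.0-fold lower number from compound 1 to compound 3 (0.70 log units; beyond the scatter). This is the first exact step at this position, since both of its compounds have true numbers, and it makes compound 3 the most active of the three compounds shown. Replacing 4-(dimethylamino)phenyl with 2-bromophenyl gives an at least 10-fold lower number from compound 2 to compound 3 (1.00 log units; beyond the scatter), and this size is only a floor because compound 2 has a limit and not an exact number: the limit of > 100000 nM in this assay, at which 1 of the 3 values shown sits.

The compounds shown leave open whether the lower number belongs to the bromine itself or to where it sits on the ring, and they give no reason for the change. A comparison of compound 3 with its 2-chlorophenyl and 4-bromophenyl counterparts would separate those two questions, while a 2-aminophenyl group would show whether a ring bearing a simple amine at that same ring position behaves more like compound 2 or compound 3.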